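The source may report more compounds than this note shows. Statements on the series, on what has been measured and on what is new or still open speak of the compounds shown alone.

Compound 1 `CCCNC(=O)/N=C(\N)NCCCc1sc(N)nc1C`: 105 nM
Compound 2 `Cc1nc(N)sc1CCCN/C(N)=N/C(=O)NCc1ccccc1`: 69.2 nM

Both compounds were tested in an assay on membranes from Sf9 cells for displacement of a labelled ligand from histamine H2 receptor (Homo sapiens), read by scintillation counting, with a stated time of 60 min; a higher number here means a weaker inhibitor, a lower number a stronger inhibitor. Compound 2 stands at the lower of the two numbers shown, yet the step of a 1.5-fold lower number from compound 1 to compound 2 (0.18 log units; within the scatter) lies within the scatter, so the two compounds cannot be told apart. Compound 3 `Cc1nc(N)sc1CCCN/C(N)=N/C(=O)NC(C)c1ccco1` is not yet measured. It differs from compound 2 in one place: 1-(furan-2-yl)ethyl in place of benzyl on an amide-type nitrogen. Among the measured compounds shown here, the only measured step that bears on this change is the one at the same amide-type nitrogen, where phenyl in place of ethyl on a saturated chain carbon bound to an amide-type nitrogen gave a 1.5-fold lower number from compound 1 to compound 2 (0.18 log units; within the scatter). Since that change left the number within the scatter, no step beyond the scatter is expected in this assay for compound 3, in either direction. Compound 3 is therefore expected to give 70 nM, with a range from 30 nM to 160 nM. This estimate means an expected step of a 1.0-fold higher number from compound 2 to compound 3 (0.00 log units; within the scatter).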

Compound 3, inhibition constant: 31.6 nM
Compound 3: the middle estimate sits 2.2-fold (0.35 log units) above what was measured; measured number inside the range.
By their numbers in this assay, from the lowest: compound 3; then compounds 2 and 1 (each within the scatter of the next).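

In this assay, among the compounds shown here, the one earlier change at this amide-type nitrogen stayed within the scatter, whereas 1-(furan-2-yl)ethyl in place of benzyl gives a 2.2-fold lower number from compound 2 to compound 3 (0.34 log units; beyond the scatter) and so shows that this position can respond, if only modestly. The same group in place of propyl gives a 3.3-fold lower number from compound 1 to compound 3 (0.52 log units; beyond the scatter), a clear separation even though compound 1 and compound 2 could not be told apart. No measurement offered here explains this gain.

This change replaces the benzene ring with furan and also adds a methyl branch, so the compounds shown cannot say which of the two matters. The groups 1-phenylethyl and furan-2-ylmethyl on the same nitrogen would separate these two parts of the change.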